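This account rests on a few compounds, and the source may have more. Where it says the series, first, only, none or still open, it means among the compounds named here.

In an assay on HL-60 cells for agonist activity at N-formyl peptide receptor 3 (Homo sapiens), read by calcium flux (on this read-out higher numbers stand for an effect only at larger amounts of compound and lower numbers for an effect already at smaller amounts), compound 1 `COc1cccc(Cc2cc(C(C)C)nn(CC(=O)Nc3ccc(Br)cc3)c2=O)c1` gives 17400 nM. Compound 2 `Cc1cc(Cc2cccc(Cl)c2)c(=O)n(CC(=O)Nc2ccc(Br)cc2)n1` is known only as far as a limit: in this assay compound 2 gives > 50000 nM, which is a limit of the assay and not a measured number. Compound 2 therefore stands at the weak end of the two values shown, at the limit of > 50000 nM in this assay, at which 1 of the 2 values shown sits. Compound 3 `Cc1cc(Cc2ccsc2)c(=O)n(CC(=O)Nc2ccc(Br)cc2)n1` differs from compound 2 in one place: thiophen-3-yl in place of 3-chlorophenyl on a saturated chain carbon bound to an aromatic carbon. For the measured compounds named here, no step between two measured compounds shows what this change does in this assay. With nothing to point at, the expectation is a step no larger than the usual scatter, in no particular direction, so compound 3 is expected to stand where compound 2 stands, with this assay most likely again reporting only a limit. The estimate for compound 3 in this assay is 50000 nM, with a range from 15000 nM to 150000 nM. The expected step from compound 2 to compound 3 is a number no higher from compound 2 to compound 3 (the limit leaves the size open).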

Compound 3, half-maximal effective concentration: > 50000 nM
Compound 3: a limit, no number; the forecaster's own chance of this, stated with the estimate: 70%; the middle value sits exactly at the limit.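

For the compounds shown here, compound 2 and compound 3 both end at a limit of the assay rather than a number, so no step between them can be read in this assay. Going by these compounds, whether thiophen-3-yl in place of 3-chlorophenyl changes the effect at all remains open.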